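Cyclohexyl for methyl on the ether oxygen of an acid

The source may hold more compounds than are shown below. What is called first, only, known or untested is meant among the compounds shown, and "the series" means these compounds.

Of the compounds shown here, two have been measured in a functional assay on the whole organism (strain Sprague-Dawley) for inhibition, with Rattus norvegicus as the target; a lower number here means that less compound is needed, a higher number that more compound is needed for the effect. Compound 1 `c1cc2ncc(-c3nn[nH]n3)cc2cc1OC1CCCCC1` gives 5 mg/kg in this assay. Compound 2 `COc1ccc2ncc(C(=O)O)cc2c1` is an acid carrying a methoxy group. In this assay compound 2 reaches only a limit, > 5 mg/kg, so no number is known for it; it stands at the limit of > 5 mg/kg in this assay, at which 1 of the 2 values shown sits. Compound 3 `O=C(O)c1cnc2ccc(OC3CCCCC3)cc2c1` keeps the acid of compound 2 and differs from it in one place: cyclohexyl in place of methyl on an oxygen on an aromatic ring. Going by the values given here, no measured pair shows this change on its own, so its effect is not known from the data. Compound 1 carries the same cyclohexyl ether and gives a number rather than a limit in this assay, which is the only hint at hand. Compound 3 is expected to give about 5 mg/kg in this assay, between 2 mg/kg and 20 mg/kg. The step expected is a number no higher from compound 2 to compound 3 (the limit leaves the size open).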

Compound 3, minimum effective dose: > 25 mg/kg
Compound 3 ended at the assay's limit; the forecaster's own chance of this, stated with the estimate: 40%; middle value at least 5.0-fold (0.69 log units) from the limit.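

With the cyclohexyl ether held in common, carboxy in place of 2H-tetrazol-5-yl on an aromatic carbon now has a readable effect in this assay, with an at least 5.0-fold higher number from compound 1 to compound 3 (0.69 log units; beyond the scatter). Going by these compounds alone, the cyclohexyl ether alone is therefore not enough to give a number in this assay, since compound 3 carries it and stands only at a limit, while compound 1 is the only one of the three compounds with a number. Compound 2 also stands only at a limit, so the step for cyclohexyl in place of methyl on an oxygen on an aromatic ring cannot be read.

On these data alone, whether that ether change has any effect on the acid therefore stays open. So does how a carboxamide or a methyl ester in place of the carboxy would read in this assay.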